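The source may report more compounds than this note shows. Statements on the series, on what has been measured and on what is new or still open speak of the compounds shown alone.

Measured in a functional assay on MC-38 cells (Mus musculus) for antiproliferative activity, read by colorimetric assay and MTT assay; a lower number here means a stronger inhibitor, a higher number a weaker inhibitor:
- compound 1 `O=[N+]([O-])c1ccc(S(=O)(=O)Nc2cccc3cc(Cl)[nH]c23)cc1`: 19 ug/mL
- compound 2 `Cc1ccc(S(=O)(=O)Nc2cccc3cc(Cl)[nH]c23)cc1`: 0.18 ug/mL
- compound 3 `Nc1ccc(S(=O)(=O)Nc2cccc3cc[nH]c23)cc1`: 6.1 ug/mL

Compound 3 holds the middle place of the three numbers. The number for compound 1 is higher at 19 ug/mL, and the number for compound 2 is lower at 0.18 ug/mL.

The next compound to be tested is compound 4 `Nc1ccc(S(=O)(=O)Nc2cccc3cc(Cl)[nH]c23)cc1`, which differs from compound 3 by chloro in place of hydrogen on an aromatic carbon.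

For the measured compounds named here, no measured pair isolates this change. Going by the values given here, the only measured step, a 110-fold lower number from compound 1 to compound 2 (2.02 log units; beyond the scatter), is large and beyond the scatter, but it is methyl in place of nitro, with chloro present in both compounds. It bears on the change only indirectly: it shows how widely values can spread among compounds that carry chloro, so the estimate stays broad. Compound 3, at 6.1 ug/mL, lies inside that spread, so its value sets no firm direction. A lower number is still the tentative expectation, with a moderate step that would probably lie beyond the scatter.

The expected change is a 7.6-fold lower number from compound 3 to compound 4 (0.88 log units; beyond the scatter).

For compound 4 the estimated value is 0.8 ug/mL, with an expected range of 0.12 ug/mL to 4 ug/mL.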

Compound 4, half-maximal inhibitory concentration: 2.9 ug/mL
The estimate for compound 4 lay 3.6-fold (0.56 log units) below the measured number; the measured number falls inside the stated range.
By their numbers in this assay, from the lowest: compound 2; then compound 4; then compound 3; then compound 1.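

In this assay, for the compounds shown here, chloro in place of hydrogen, on the aromatic carbon next to the ring nitrogen, gives a 2.1-fold lower number from compound 3 to compound 4 (0.32 log units; beyond the scatter) as a modest step, the first direct reading of this position. With chloro held constant, amino in place of methyl gives a 16-fold higher number from compound 2 to compound 4 (1.21 log units; beyond the scatter) and amino in place of nitro gives a 6.6-fold lower number from compound 1 to compound 4 (0.82 log units; beyond the scatter) in the opposite sense, so amino ranks inside the range set by methyl and nitro at the site varied among compounds 1, 2 and 4. Both of these steps exceed the chloro step in size, and nothing available explains the size or direction of any of them.

On these data alone, whether the chloro step carries over when methyl or nitro stands in place of amino stays open, as it is read only in the amino pair. Also open, as far as these compounds go, is how bromo or nitrile would read at the chloro position, and how methoxy or a carboxylic acid would read at the site that carries amino.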